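Sulfonyl hydrazides of a chloroanilino pyridine carboxamide core

A few compounds are considered here, and "the series" means these few. Any claim that something is new, unique, unknown or untested is made for them only; others in the source may bear on it.

Measured so far:
compound 1 `CC(=O)Nc1ccc(S(=O)(=O)NNC(=O)c2cccnc2Nc2ccc(Cl)cc2)cc1` in a functional assay on OVCAR-3 cells (Homo sapiens) for antiproliferative activity; a lower number here means that less compound is tolerated, a higher number that more compound is tolerated: > 100000 nM
compound 2 `O=C(NNS(=O)(=O)c1ccc(F)cc1)c1cccnc1Nc1ccc(Cl)cc1Cl` with > 100000 nM

Compound 1 gives only a limit in this assay, not a number. Compound 2 likewise reports a limit. the limit of > 100000 nM in this assay, at which 2 of the 2 values shown sit. Compound 3 `O=C(NNS(=O)(=O)c1ccc(Cl)cc1Cl)c1cccnc1Nc1ccc(Cl)cc1` is not yet measured; it carries 2,4-dichlorophenyl in place of 4-acetamidophenyl on a sulfonyl sulfur, that is 2,4-dichlorophenyl in place of 4-acetamidophenyl on a sulfonyl sulfur. With both measured compounds sitting at the limit, no step beyond the scatter is expected in this assay, in either direction. Compound 3 is therefore expected at 100000 nM, within 20000 nM to 300000 nM. The estimated step of a number no higher from compound 1 to compound 3 (the limit leaves the size open) is none beyond the scatter.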

Compound 3, concentration lethal to 50% of the cells: > 100000 nM
Compound 3: a limit, no number; the forecaster's own chance of this, stated with the estimate: 80%; the middle value lies on the limit itself.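

In this assay, going by these compounds alone, compound 3 gives > 100000 nM, a limit and not a number; no step from compound 1 to compound 3 can be read. The compounds shown leave open which group on the sulfonyl sulfur, if any, would give a number in this assay.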